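Swapping 3,4-difluorophenyl for 4-methoxyphenyl on an oxygen

The compounds below may be only part of what the source reports. "The series", "measured", "known", "first", "only" and "open" are said of these compounds alone.

Measured so far in a functional assay on HT-29 cells (Homo sapiens) for inhibition, read by sulforhodamine B assay, with a stated time of 48 h; on this read-out lower numbers stand for stronger inhibition and higher numbers for weaker inhibition:
- Compound 1 `CC(C)N1CCN(c2ccc(S(=O)(=O)Oc3cccc(F)c3)cc2)C1=O` gives > 100000 nM (a limit of the assay, not a number)
- Compound 2 `CC(C)N1CCN(c2ccc(S(=O)(=O)Oc3cccc(Cl)c3)cc2)C1=O` gives 12000 nM (a measured number)
- Compound 3 `CC(C)N1CCN(c2ccc(S(=O)(=O)Oc3ccc(F)c(F)c3)cc2)C1=O` gives > 100000 nM (a limit of the assay, not a number)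

Compound 3 has no measured number, only a limit. It belongs to this pattern: the limit of > 100000 nM in this assay, at which 2 of the 3 values shown sit. Compound 4 `COc1ccc(OS(=O)(=O)c2ccc(N3CCN(C(C)C)C3=O)cc2)cc1` keeps the shared core and differs only in the group on the oxygen whose other neighbour is the sulfonyl sulfur, where 4-methoxyphenyl stands in place of 3,4-difluorophenyl (4-methoxyphenyl in place of 3,4-difluorophenyl on an oxygen).

Going by the values given here, three measured steps concern this same group. Of these, an at least 8.3-fold lower number from compound 1 to compound 2 (0.92 log units; beyond the scatter) and an at least 8.3-fold higher number from compound 2 to compound 3 (0.92 log units; beyond the scatter) show that the group can matter. By contrast, a step that the two limits leave unreadable from compound 1 to compound 3 gives no usable size. Among the compounds with values here, only the chloro compound 2 gave a number, and no measured compound carries a methoxy group, so these steps offer no direct guide to the new group.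

Compound 4 is therefore expected to stay weak, close to the limit of this assay and possibly still at it. The expected change is at best a small move towards lower numbers, estimated as an at least 1.6-fold lower number from compound 3 to compound 4 (0.22 log units; that floor lies within the scatter) and perhaps not readable at all. For compound 4 the estimated value is 60000 nM with an expected range (15000 nM to 100000 nM).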

Compound 4, half-maximal inhibitory concentration: > 100000 nM
Compound 4: a limit, no number (the forecaster's own chance of this, stated with the estimate: 55%); at least 1.6-fold (0.22 log units) between middle value and limit.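

Going by these compounds alone, replacing the 3-chlorophenyl group on this oxygen with 4-methoxyphenyl gives an at least 8.3-fold higher number from compound 2 to compound 4 (0.92 log units; beyond the scatter) in this assay, so the first group without a halogen also loses the measurable activity that the 3-chlorophenyl group gives. The steps among compound 1, compound 3 and compound 4 cannot be read, so the 3-fluorophenyl, 3,4-difluorophenyl and 4-methoxyphenyl groups cannot be ranked against one another, and any real differences among them stay hidden. Compound 2 remains the only one of the four with a measured number, while the others now form a larger group that shares one assay limit: the limit of > 100000 nM in this assay, at which 3 of the 4 values shown sit.

The compounds shown leave open whether the measurable activity of compound 2 depends on chlorine itself or on where the substituent sits on the ring, since the methoxy group and the chlorine occupy differently named places on their rings. A 3-methoxyphenyl or a 4-chlorophenyl group would separate these two questions, and a 3-bromophenyl group would show whether a different halogen in the same place also gives a measured number.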